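Capping the Pyrrolidine Nitrogen of Compound 1

This account rests on a few compounds, and the source may have more. Where it says the series, first, only, none or still open, it means among the compounds named here.

Measured compounds:
compound 1, `CN1CCN(c2ccc(Nc3ncc4nc(Nc5ccccc5)n([C@H]5CCNC5)c4n3)cc2)CC1`, 530 nM
compound 2, `CN1CCN(c2ccc(Nc3ncc4nc(Nc5ccc(F)cc5)n(CCNS(=O)(=O)C5CC5)c4n3)cc2)CC1`, 50 nM

Of the compounds shown here, two have been measured in a functional assay on HCC827 cells (Homo sapiens) for antiproliferative activity, read by MTT assay, with a stated time of 72 h; a higher number here means a weaker inhibitor, a lower number a stronger inhibitor. Compound 1 gives 530 nM, the higher of the two numbers. Among the compounds with values here, compound 2 gives 50 nM, a gap that lies beyond the scatter; as compound 2 differs from compound 1 at more than one place, the pair shows only that compound 2 has the lower number, not which change carries it.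

Compound 3, `CNC(=O)CN1CC[C@H](n2c(Nc3ccccc3)nc3cnc(Nc4ccc(N5CCN(C)CC5)cc4)nc32)C1`, has not been measured. It differs from compound 1 by (methylcarbamoyl)methyl in place of hydrogen on an amine nitrogen in a ring. Within the data shown here, no measured pair isolates this change, so its size is not known from the data. Compound 2 carries a substituent on its amine nitrogen outside a ring together with a further change, and its lower number is the only hint available, a weak one. A step toward a lower number is therefore expected for compound 3, but a small one, and it may fall within the scatter. The expected step of a 1.8-fold lower number from compound 1 to compound 3 (0.25 log units; within the scatter) is modest. Compound 3 is expected to give about 300 nM, with a range from 100 nM to 900 nM.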

Compound 3, half-maximal inhibitory concentration: 170 nM
Compound 3: middle estimate off by 1.8-fold (0.25 log units), on the high side; the measured number falls inside the stated range.
By their numbers in this assay, from the lowest: compound 2; then compound 3; then compound 1.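

In this assay, the amine nitrogen in the ring of compound 1 accepts a substituent without loss of activity: (methylcarbamoyl)methyl in place of hydrogen gives a 3.1-fold lower number from compound 1 to compound 3 (0.49 log units; beyond the scatter). Within the data shown here, this is the first change at this position whose effect can be read on its own, since compound 1 and compound 2 differ at more than one place and could not assign their gap to any single change. Nothing available explains why this group lowers the number, so the step stands as an observation only.

The compounds shown do not tell whether the step depends on the amide, with its carbonyl and amide hydrogen, or comes simply from replacing the hydrogen on this nitrogen, a question that a methyl, an acetyl or a carboxylic acid at the same place would address. They also leave open how a longer chain between the ring nitrogen and the amide would read, and whether the step would hold on a compound that differs from compound 1 elsewhere.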